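The source may hold more compounds than are shown below. What is called first, only, known or untested is meant among the compounds shown, and "the series" means these compounds.

Measured compounds:
compound 1, `CN1CCN(CC(=O)Nc2ccc(-c3nc4cc(C(F)(F)F)ccc4n3C)cc2)CC1`, gives 44000 nM in an ADME assay on MDBK cells (Bos taurus) for cytotoxicity, read by MTT assay, with a stated time of 96 h; a higher number here means that more compound is tolerated, a lower number that less compound is tolerated.
compound 2, `O=C(CCl)Nc1ccc(-c2nc3cc(C(F)(F)F)ccc3[nH]2)cc1`, gives 17000 nM in this assay.
compound 3, `O=C(CN1CCCC1)Nc1ccc(-c2nc3ccccc3[nH]2)cc1`, gives 70000 nM in this assay.

Among these three numbers compound 2 stands lowest in this assay, that is, it is the least tolerated of the set. The nearest number is that of compound 1, which lies higher by a margin beyond the usual scatter; compound 3 lies further away still, also beyond the scatter. Going by the values given here, none of the three measured compounds differ from one another in a single place, so no step between measured compounds can be read off directly.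

Compound 4, `O=C(O)CCC(=O)Nc1ccc(-c2nc3cc(C(F)(F)F)ccc3[nH]2)cc1`, has not yet been measured in this assay. It differs from compound 2 in one place: carboxymethyl in place of chloro on a saturated chain carbon bound to a carbonyl carbon. Among the compounds with values here, with no measured pair showing this exchange, the expectation rests on where compound 2 stands and on the change itself. The step of a 3.5-fold higher number from compound 2 to compound 4 (0.55 log units; beyond the scatter) is expected to move the number upward, toward more compound being tolerated, by an amount somewhat beyond the scatter, though with considerable uncertainty in either direction. For compound 4 the estimated value is 60000 nM, with a range from 25000 nM to 150000 nM.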

Compound 4, half-maximal cytotoxic concentration: > 100000 nM
Compound 4 ended at the assay's limit; the forecaster's own chance of this, stated with the estimate: 15%; at least 1.6-fold (0.22 log units) between middle value and limit.
By their numbers in this assay, from the lowest: compound 2; then compounds 1 and 3 (each within the scatter of the next). At a limit, above all of these: compound 4.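

In this assay, going by these compounds alone, the saturated chain carbon bound to a carbonyl carbon is the first place where a single exchange can be read: carboxymethyl in place of chloro gives an at least 5.8-fold higher number from compound 2 to compound 4 (0.76 log units; beyond the scatter). Compound 4 carries a limit of the assay and not a number, and the printed size of the step is therefore only a floor: the limit of > 100000 nM in this assay, at which 1 of the 4 values shown sits. With the shared core unchanged in this pair, the lowest standing of compound 2 among the compounds shown is tied at least in part to the chloro on this carbon, which the earlier compounds, none of them differing in one place, could not show.

This single pair does not separate the loss of the chloro from the arrival of the carboxylic acid or from the longer chain, and it gives no ceiling for how much compound is tolerated once the chloro has gone. A methyl ester of the acid, or a plain propyl chain on the same carbon over the same core, would tell these apart.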